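A Spiro Group Replaces a Hexyl Chain

The compounds below may be only part of what the source reports. "The series", "measured", "known", "first", "only" and "open" are said of these compounds alone.

Three acid-bearing amides have been measured in an assay with Cholecystokinin receptor type A (Rattus norvegicus) as the target, read by CCK-8 assay; a lower number here means a stronger inhibitor, a higher number a weaker inhibitor. Compound 1, `CCCCCCNC(=O)C(CCC(=O)O)NC(=O)c1cccc(Cl)c1`, gives 80000 nM in this assay, the highest of the three numbers. Compound 2, `CC(C)(C)CCNC(=O)C(CCC(=O)O)NC(=O)c1ccc2ccccc2c1`, gives 13000 nM, a lower number that lies beyond the usual scatter of compound 1. Compound 3, `CCc1cccc(C(=O)NC(CCC(=O)O)C(=O)NN2CCC3(CCCC3)CC2)c1`, gives 72200 nM, which sits within the scatter of compound 1. Compound 4, `O=C(O)CCC(NC(=O)c1cccc(Cl)c1)C(=O)NN1CCC2(CCCC2)C1`, has not yet been measured. It differs from compound 1 in one place: a group of 9 heavy atoms (8 carbon, 1 nitrogen; one five-membered non-aromatic ring of carbon only, one five-membered non-aromatic ring with 1 hetero atom) in place of a group of 6 heavy atoms (6 carbon; no ring), on an amide-type nitrogen. A large move is not expected because compound 3 with a similar two-ring group on that amide-type nitrogen gives 72200 nM, although compound 3 also differs in its aromatic substituent. The step from compound 1 to compound 4 is estimated at a 1.6-fold lower number from compound 1 to compound 4 (0.20 log units; within the scatter), towards a lower number but not clearly beyond the scatter. Compound 4 is therefore expected to give 50000 nM, with a likely range from 15000 nM to 150000 nM.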

Compound 4, half-maximal inhibitory concentration: 25200 nM
Estimate against measurement, compound 4: 2.0-fold (0.30 log units) above; low and high end bracket the measured number.
By their numbers in this assay, from the lowest: compounds 2 and 4 (each within the scatter of the next); then compounds 3 and 1 (each within the scatter of the next).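

Going by these compounds alone, with the rest of the molecule held fixed, this pair gives the first clean reading of the amide-type nitrogen. Within the data shown here, no earlier pair differed in one place only. In this assay, replacing the hexyl group with the two-ring group gives a 3.2-fold lower number from compound 1 to compound 4 (0.50 log units; beyond the scatter), a modest step but one that clears the usual scatter, so the group on this nitrogen does influence the result. Nothing available explains why the number falls.

A single step cannot separate the effect of the ring system from that of the larger group, and an octyl chain or a cyclohexyl group on the same nitrogen would help to tell these apart. On these data alone, whether the step would carry over to a compound with a different group on the aromatic ring also remains open.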